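Replacing the Sulfonyl Cap with an Aliphatic Amide

The compounds below may be only part of what the source reports. "The series", "measured", "known", "first", "only" and "open" are said of these compounds alone.

Compound 1 `CCCn1c(=O)c2nc(-c3ccc(OCC(=O)NCCN=C(S)Nc4ccc(OC)cc4)cc3)[nH]c2n(CCC)c1=O` — in an assay on brain for binding affinity to adenosine receptor A1 (Rattus norvegicus), read by radioligand binding (a higher number here means a weaker inhibitor, a lower number a stronger inhibitor), compound 1 gives 33.2 nM.
Compound 2 `CCCn1c(=O)c2nc(-c3ccc(OCC(=O)NCCN=C(S)Nc4ccc(F)cc4)cc3)[nH]c2n(CCC)c1=O` — in this assay compound 2 gives 15.5 nM.
Compound 3 `CCCn1c(=O)c2nc(-c3ccc(OCC(=O)NCCNS(=O)(=O)c4ccc(C)cc4)cc3)[nH]c2n(CCC)c1=O` — in this assay compound 3 gives 72 nM.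

The three compounds share a core and differ only in the group at the end of the chain. Compound 3 stands weakest of the three in this assay: the step of a 2.2-fold higher number from compound 1 to compound 3 (0.34 log units; beyond the scatter) and the step of a 4.6-fold higher number from compound 2 to compound 3 (0.67 log units; beyond the scatter) both lie beyond the scatter, while the step of a 2.1-fold lower number from compound 1 to compound 2 (0.33 log units; beyond the scatter) is modest.

Compound 4 `CCCn1c(=O)c2nc(-c3ccc(OCC(=O)NCCNC(=O)CCCCC(C)=O)cc3)[nH]c2n(CCC)c1=O` is not yet measured. Its change from compound 3 is (4-acetylbutyl)carbonyl in place of (4-methylphenyl)sulfonyl on an amine nitrogen. The two measured steps that touch this position, a 2.2-fold higher number from compound 1 to compound 3 (0.34 log units; beyond the scatter) and a 4.6-fold higher number from compound 2 to compound 3 (0.67 log units; beyond the scatter), were modest, and neither swaps a sulfonyl for an aliphatic carbonyl, so the direction is uncertain. A step of similar modest size in either direction, or none beyond the scatter, is expected in this assay.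

For compound 4 the expected step is a 1.2-fold lower number from compound 3 to compound 4 (0.08 log units; within the scatter). Compound 4 is estimated at 60 nM, with a range from 20 nM to 200 nM.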

Compound 4, inhibition constant: 44 nM
The estimate for compound 4 lay 1.4-fold (0.13 log units) above the measured number, within the range that was stated.
By their numbers in this assay, from the lowest: compound 2; then compounds 1, 4 and 3 (each within the scatter of the next, the first and the last beyond it).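

In this assay, exchanging the (4-methylphenyl)sulfonyl group for the ringless (4-acetylbutyl)carbonyl on this amine nitrogen gives a 1.6-fold lower number from compound 3 to compound 4 (0.21 log units; within the scatter), so here an aliphatic carbonyl cap without a ring can stand in for the aromatic sulfonyl cap with no step beyond the scatter. Set against the other two end groups, compound 4 shows a 1.3-fold higher number from compound 1 to compound 4 (0.12 log units; within the scatter), also within the scatter, but a 2.8-fold higher number from compound 2 to compound 4 (0.45 log units; beyond the scatter), which lies beyond it, so the fluoro-bearing end group of compound 2 keeps its lead over this chain. Nothing available bears on why the numbers fall this way.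

From the compounds shown here alone, whether the ketone in the chain matters stays open: a plain hexanoyl chain, a carboxylic acid at the chain end or a longer chain could each test that. So does the separate share of the ring and the sulfonyl in this exchange, which a benzoyl group on the same nitrogen would address.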